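The compounds below may be only part of what the source reports. "The series", "measured", "known", "first", "only" and "open" are said of these compounds alone.

Measured compounds:
compound 1 `COc1cc2c(Oc3ccc(NC(=O)c4nn(-c5ccccc5)c(=O)cc4C)cc3F)ccnc2cc1OCCCN1CCCC1`: 460 nM
compound 2 `COc1cc2c(Oc3ccc(NC(=O)c4nn(-c5ccccc5)c(=O)cc4C)cc3F)ccnc2cc1OCCCN1CCCCC1`: 280 nM

In a functional assay on NCI-H460 cells (Homo sapiens) for inhibition, read by MTT assay, with a stated time of 72 h (a lower number here means a stronger inhibitor, a higher number a weaker inhibitor), compound 2 gives 280 nM and compound 1 gives 460 nM; the two lie within the scatter of each other. Compound 3 `COc1cc2c(Oc3ccc(NC(=O)c4nn(-c5ccccc5C)c(=O)cc4C)cc3F)ccnc2cc1OCCCN1CCCCC1` has not yet been measured. It differs from compound 2 in one place: methyl in place of hydrogen on an aromatic carbon. Going by the values given here, the only measured step, a 1.6-fold lower number from compound 1 to compound 2 (0.22 log units; within the scatter), concerns a different change, piperidin-1-yl in place of pyrrolidin-1-yl, and stayed within the scatter; no measured pair alters the phenyl of the shared core, so nothing here speaks directly to a methyl in place of hydrogen there. The expectation is therefore that compound 3 stays within the scatter of compound 2, an expected step of no change at the digits printed from compound 2 to compound 3 (within the scatter). The estimate for compound 3 in this assay is 280 nM, with a range from 110 nM to 700 nM.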

Compound 3, half-maximal inhibitory concentration: 3220 nM
Estimate against measurement, compound 3: 12-fold (1.06 log units) below, outside the stated range (above it).
By their numbers in this assay, from the lowest: compounds 2 and 1 (each within the scatter of the next); then compound 3.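

In this assay the change from phenyl to 2-methylphenyl gives a 12-fold higher number from compound 2 to compound 3 (1.06 log units; beyond the scatter) in the direction of a weaker inhibitor, whereas the earlier swap of pyrrolidin-1-yl for piperidin-1-yl, a 1.6-fold lower number from compound 1 to compound 2 (0.22 log units; within the scatter), stayed within the scatter. This aromatic carbon, ortho to a large group, is therefore the first place among the compounds shown where a change matters, and there the entry of methyl, a single carbon, is enough to move the number beyond the scatter. Nothing available explains the size of this step.

Only hydrogen and methyl are shown at this carbon, so it remains open whether fluorine, chlorine or methoxy there would give a similar step. Also open, going by these compounds, is how methyl would read on another carbon of the same phenyl.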